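Methyl for phenyl on the aryl of compound 2

This account rests on a few compounds, and the source may have more. Where it says the series, first, only, none or still open, it means among the compounds named here.

Measured compounds:
compound 1 `C=C[C@@H]1OC(c2ccc(-c3ccccc3)cc2)=N[C@H]1Sc1ccccc1`: in an assay on isolated protein for inhibition of matrix metalloproteinase-9 (Homo sapiens) (a higher number here means a weaker inhibitor, a lower number a stronger inhibitor), compound 1 gives > 100000 nM, a limit of the assay.
compound 2 `C=C[C@@H]1OC(c2ccc(-c3ccccc3)cc2)=N[C@H]1CO`: in this assay compound 2 gives 24000 nM.

Among the compounds with values here, compound 2 holds the only number in this assay; the other value is a limit (the limit of > 100000 nM in this assay, at which 1 of the 2 values shown sits). Within the data shown here, the single measured step, an at least 4.1-fold lower number from compound 1 to compound 2 (0.61 log units; beyond the scatter), concerns the saturated ring carbon and so does not bear on the change now in question. Compound 3 `C=C[C@@H]1OC(c2ccc(C)cc2)=N[C@H]1CO` differs from compound 2 by methyl in place of phenyl on an aromatic carbon. Among the measured compounds shown here, no measured step covers this change, so the expectation is loose. A weaker inhibition is expected, with the step estimated as a 3.3-fold higher number from compound 2 to compound 3 (0.52 log units; beyond the scatter). Compound 3 is estimated at 80000 nM, within 20000 nM to 300000 nM, and may return only a limit.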

Compound 3, inhibition constant: 68000 nM
Estimate against measurement, compound 3: 1.2-fold (0.07 log units) above, and the stated range covers the measured number.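

Within the data shown here, on this aromatic carbon, this assay gives a 2.8-fold higher number from compound 2 to compound 3 (0.45 log units; beyond the scatter) and shows for the first time that the biaryl end can be cut back to a methyl with only a modest step. Inhibition therefore does not rest wholly on the phenyl, although both compounds remain weak. Among these compounds, compound 3 keeps a number, and the only limit stays with compound 1: the limit of > 100000 nM in this assay, at which 1 of the 3 values shown sits.

Open, from the compounds shown here alone, is whether the step tracks group size on this aromatic carbon. A methoxy, an ethyl chain or a carboxylic acid there would test this.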